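The source may hold more compounds than are shown below. What is called first, only, known or untested is meant among the compounds shown, and "the series" means these compounds.

Compound 1 `CC1(C)CC(=O)C2=C(C1)OC(=O)C(NC(=O)c1ccccc1)C2c1ccc([N+](=O)[O-])cc1` and compound 2 `CC1(C)CC(=O)C2=C(C1)OC(=O)C(NC(=O)c1ccccc1)C2c1cccs1` share one core and differ only in the group on the saturated ring carbon. In a functional assay on SW 1116 cells (Homo sapiens) for cytotoxicity, read by MTT assay, with a stated time of 24 h, tested at 0.1 ug/mL (a higher number here means a weaker effect of the compound at the concentration tested, a lower number a stronger effect), compound 1 gives 107%, and compound 2 gives 94.5%; the step is a number 12.5 percentage points lower from compound 1 to compound 2 (beyond the scatter). On these two numbers compound 2 stands lowest, with compound 1 the nearest. Compound 3 `CC1(C)CC(=O)C2=C(C1)OC(=O)C(NC(=O)c1ccccc1)C2c1ccco1` carries the change (furan-2-yl in place of thiophen-2-yl on a saturated ring carbon). Among the measured compounds shown here, no measured step shows this exchange; the single step from compound 1 to compound 2 concerns a different group and does not settle its size. For the measured compounds named here, with no direct precedent, no step beyond the scatter in this assay is expected, so the estimated step is a number 0.5 percentage points higher from compound 2 to compound 3 (within the scatter). Compound 3 is expected to give 95%, within 80% to 110%.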

Compound 3, a percentage reported as activity, at one concentration (the size of the read-out at that concentration, not a potency): 79.3%
For compound 3 the middle estimate is 15.7 percentage points above the measured one; measured number below the stated range.
By their numbers in this assay, from the lowest: compound 3; then compound 2; then compound 1.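

At this saturated ring carbon, furan-2-yl in place of thiophen-2-yl keeps the heavy-atom count and changes only the ring hetero atom, from sulfur to oxygen, yet the read-out in this assay still moves: a number 15.2 percentage points lower from compound 2 to compound 3 (beyond the scatter). The position therefore distinguishes between the two five-membered aromatic rings, and the furan-2-yl group also gives the widest separation from 4-nitrophenyl, a number 27.7 percentage points lower from compound 1 to compound 3 (beyond the scatter). Nothing available explains the difference between these rings. Open, going by these compounds, is whether a pyrrol-2-yl group or a phenyl ring bearing an amine at this carbon would lower the number further. Also open, on these data alone, is whether the order of the three groups holds when the benzamido group is replaced.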